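This account rests on a few compounds, and the source may have more. Where it says the series, first, only, none or still open, it means among the compounds named here.

Compound 1 `CNC1=Nc2ccc(Cl)cc2C(C)(C)C1` gives 91.9% in a functional assay on MDA-MB-231 cells (Homo sapiens) for cytotoxicity, read by MTT assay, with a stated time of 72 h, tested at 1 uM, in the absence of a further agent; a lower number here means a stronger effect, a higher number a weaker effect of the compound at the concentration tested. Compound 2 `CCNC1=Nc2ccc(Cl)cc2C(C)(C)C1` gives 89.7%. Compound 3 `CN(C)CCCNC1=Nc2ccc(Cl)cc2C(C)(C)C1` gives 54.1%.

Compound 3 stands lowest of the three numbers; the nearest is compound 2 and the furthest compound 1, both beyond the scatter. Compound 4 `CN(C)CCNC1=Nc2ccc(Cl)cc2C(C)(C)C1` differs from compound 3 by dimethylamino in place of (dimethylamino)methyl on a saturated chain carbon, two bonds along the chain from an amine nitrogen. Within the data shown here, two measured steps bear on this: a number 37.8 percentage points lower from compound 1 to compound 3 (beyond the scatter) and a number 35.6 percentage points lower from compound 2 to compound 3 (beyond the scatter), both large, while a number 2.2 percentage points lower from compound 1 to compound 2 (within the scatter) is within the scatter. Compound 4 keeps a dimethylamino-bearing chain, shortened by one carbon, so a number close to compound 3 is expected, with at most a modest rise, giving a number 7.9 percentage points higher from compound 3 to compound 4 (within the scatter). Compound 4 is therefore estimated at 62%, between 45% and 82%.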

Compound 4, a percentage reported as activity, at one concentration (the size of the read-out at that concentration, not a potency): 66.9%
For compound 4 the middle estimate is 4.9 percentage points below the measured one; measured number inside the range.
By their numbers in this assay, from the lowest: compound 3; then compound 4; then compounds 2 and 1 (each within the scatter of the next).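

Shortening the chain from 3-(dimethylamino)propyl to 2-(dimethylamino)ethyl changes the outcome in this assay, with a number 12.8 percentage points higher from compound 3 to compound 4 (beyond the scatter) as the step, so chain length matters and not only the presence of dimethylamino. The shorter chain still separates from the simple alkyl compounds, with a number 22.8 percentage points lower from compound 2 to compound 4 (beyond the scatter) and a number 25 percentage points lower from compound 1 to compound 4 (beyond the scatter) as the two steps. Adding (dimethylamino)methyl gives comparable drops in two pairs: the same change on two cores in this assay, a number 35.6 percentage points lower (beyond the scatter) from compound 2 to compound 3 and a number 25 percentage points lower (beyond the scatter) from compound 1 to compound 4, 10.6 percentage points apart, within the scatter of two such steps.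

As far as these compounds go, whether a longer chain such as 4-(dimethylamino)butyl would lower the number further stays open. So does whether a morpholine or a primary amine could replace dimethylamino at the chain end.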